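The source may hold more compounds than are shown below. What is called first, only, known or untested is meant among the compounds shown, and "the series" means these compounds.

In a functional assay on HCT-116 cells (Homo sapiens) for antiproliferative activity, with a stated time of 72 h (on this read-out lower numbers stand for stronger inhibition and higher numbers for weaker inhibition), compound 1 (`COc1ccc(/C=C/c2nc3ccccc3c(=O)[nH]2)cc1`) gives > 25000 nM as a limit and not a number. Compound 2 (`CCOc1ccc(/C=C/c2nc3ccccc3c(=O)[nH]2)cc1`) gives > 25000 nM as a limit too, and so stands only at the limit of > 25000 nM in this assay, at which 2 of the 2 values shown sit, with no number to work from. Compound 3 (`CCCCOc1ccc(/C=C/c2nc3ccccc3c(=O)[nH]2)cc1`) follows from compound 2 by ethyl in place of hydrogen on a saturated chain carbon, two bonds along the chain from an oxygen on an aromatic ring in the change from ethoxy to butoxy. Within the data shown here, the sole measured step is a step that the two limits leave unreadable from compound 1 to compound 2 and offers no size to carry over, so no step beyond the scatter is expected in this assay in either direction. The expected change is a number no higher from compound 2 to compound 3 (the limit leaves the size open) by estimate. Compound 3 is estimated at 25000 nM (expected range 10000 nM to 50000 nM).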

Compound 3, half-maximal inhibitory concentration: > 25000 nM
Compound 3 gave a limit, no number (the forecaster's own chance of this, stated with the estimate: 75%); the middle value sits exactly at the limit.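

Compound 3 gives > 25000 nM in this assay, a limit and not a number, and the steps linking compound 1, compound 2 and compound 3 cannot be read. On these data alone, whether the change from ethoxy to butoxy alters inhibition at all stays open.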